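Aryl variation on the dihydropyridine ester series

A few compounds are considered here, and "the series" means these few. Any claim that something is new, unique, unknown or untested is made for them only; others in the source may bear on it.

Measured so far:
compound 1 `CC1=C(C(=O)OCC2CCN(C(=O)OC(C)(C)C)CC2)C(c2cccc(C#N)c2)C2=C(CC(C)(C)CC2=O)N1`, 220 nM
compound 2 `CC1=C(C(=O)OCC2CCN(C(=O)OC(C)(C)C)CC2)C(c2cccc(C(F)(F)F)c2)C2=C(CC(C)(C)CC2=O)N1`, 760 nM

In an assay on HEK293 cells for inhibition of neurogenic locus notch homolog protein 1 (Homo sapiens), read by a luciferase reporter and resazurin assay, with a stated time of 16 h (a higher number here means a weaker inhibitor, a lower number a stronger inhibitor), compound 1 gives 220 nM and compound 2 gives 760 nM. Among the measured compounds shown here, the only step between them is a 3.5-fold higher number from compound 1 to compound 2 (0.54 log units; beyond the scatter). Compound 2 thus holds the highest of the two numbers, with compound 1 the nearest and lower.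

Compound 3 `CC1=C(C(=O)OCC2CCN(C(=O)OC(C)(C)C)CC2)C(c2ccc(Br)cc2F)C2=C(CC(C)(C)CC2=O)N1` is not yet measured. Its difference from compound 2 is 4-bromo-2-fluorophenyl in place of 3-(trifluoromethyl)phenyl on a saturated ring carbon. For the measured compounds named here, no measured step covers this exchange: the one step in hand, a 3.5-fold higher number from compound 1 to compound 2 (0.54 log units; beyond the scatter), swaps one group on the aryl ring for another at the same place and shows only that the aryl substitution pattern can move this assay by a modest amount. It gives no direction for a bromine and a fluorine replacing trifluoromethyl.

With that single, indirect precedent the expectation for compound 3 is a number close to compound 2, with a step of a 1.5-fold lower number from compound 2 to compound 3 (0.18 log units; within the scatter) that may well sit within the scatter. The estimate for compound 3 in this assay is 500 nM, ranging from 150 nM to 1800 nM.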

Compound 3, half-maximal inhibitory concentration: > 10000 nM
Compound 3 ended at the assay's limit; the forecaster's own chance of this, stated with the estimate: 5%; at least 20-fold (1.30 log units) between middle value and limit.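

In this assay compound 3 gives > 10000 nM which is a limit of the assay and not a number: the limit of > 10000 nM in this assay, at which 1 of the 3 values shown sits. Within the core shared by these compounds, 4-bromo-2-fluorophenyl in place of 3-(trifluoromethyl)phenyl gives an at least 13-fold higher number from compound 2 to compound 3 (1.11 log units; beyond the scatter) and 4-bromo-2-fluorophenyl in place of 3-cyanophenyl gives an at least 45-fold higher number from compound 1 to compound 3 (1.65 log units; beyond the scatter) on the same saturated ring carbon. The earlier exchange at this position, a 3.5-fold higher number from compound 1 to compound 2 (0.54 log units; beyond the scatter), showed only a modest shift, whereas these new steps show that the choice of aryl group here can carry the series from measurable inhibition to the limit of the assay.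

The exchange replaces one substituted phenyl with another that differs in both its substituents and their positions on the ring, so the compounds shown cannot separate the contribution of the 4-bromo group from that of the 2-fluoro group or from the loss of the 3-substituent. Also open, going by these compounds, is how this position would respond to a phenyl carrying an amine or a carboxylic acid, and whether either 4-bromophenyl or 2-fluorophenyl alone would keep the inhibition seen with the 3-substituted rings.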